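A few compounds are considered here, and "the series" means these few. Any claim that something is new, unique, unknown or untested is made for them only; others in the source may bear on it.

- Compound 1 `C/C(=C\CC/C(C)=C/CC[C@@H]1[C@@]2(C)CCC(=O)C(C)(C)[C@H]2CC[C@@]1(C)O)CC/C=C(\C)C(=O)OCc1cn(-c2ccc(F)c(Cl)c2)nn1`: > 150000 nM
- Compound 2 `COc1ccc(-n2cc(COC(=O)/C(C)=C/CC/C(C)=C/CC/C(C)=C/CC[C@@H]3[C@@]4(C)CCC(=O)C(C)(C)[C@H]4CC[C@@]3(C)O)nn2)cc1`: > 150000 nM

In a functional assay on A549 cells (Homo sapiens) for antiproliferative activity, read by MTT assay, with a stated time of 48 h (a higher number here means a weaker inhibitor, a lower number a stronger inhibitor), compound 2 gives > 150000 nM, which is a limit and not a number. Compound 1 gives > 150000 nM, which is also a limit. The whole measured picture is therefore (the limit of > 150000 nM in this assay, at which 2 of the 2 values shown sit). Compound 3 `C/C(=C\CC/C(C)=C/CC[C@@H]1[C@@]2(C)CCC(=O)C(C)(C)[C@H]2CC[C@@]1(C)O)CC/C=C(\C)C(=O)OCc1cn(-c2cccc(Cl)c2)nn1` has 3-chlorophenyl in place of 4-methoxyphenyl on an aromatic nitrogen. For the measured compounds named here, the one measured step that bears on this change is a step that the two limits leave unreadable from compound 1 to compound 2, where 4-methoxyphenyl replaced 3-chloro-4-fluorophenyl on an aromatic nitrogen. Going by the values given here, it offers no size to carry over, so no step of known size or direction is expected in this assay, and compound 3 will most likely stay at the same limit. The expected step is a number no higher from compound 2 to compound 3 (the limit leaves the size open). For compound 3 the estimated value is 150000 nM. The expected range for compound 3 runs from 70000 nM to 300000 nM.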

Compound 3, half-maximal inhibitory concentration: 147000 nM
For compound 3 the middle estimate is 1.0-fold (0.01 log units) above the measured one; the range from low to high includes it.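

In this assay, compound 3 gives 147000 nM, the only one of the three results that is a number rather than a limit. Placing 3-chlorophenyl in place of 4-methoxyphenyl on the aromatic nitrogen gives an at least 1.0-fold lower number from compound 2 to compound 3 (0.00 log units; that floor lies within the scatter), and hydrogen in place of fluoro on an aromatic carbon gives an at least 1.0-fold lower number from compound 1 to compound 3 (0.00 log units; that floor lies within the scatter), so neither change is shown to do more than ordinary scatter. The three phenyl groups tried on this nitrogen leave the results at or close to one edge of the assay: the limit of > 150000 nM in this assay, at which 2 of the 3 values shown sit.

As far as these compounds go, how far compound 1 and compound 2 lie past their limits stays open, so the true size of both steps is unknown. Also open, from the compounds shown here alone, is whether an amine or a carboxylic acid on the phenyl ring, or an alkyl chain in its place, would move the value clearly away from that limit.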